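The source may hold more compounds than are shown below. What is called first, only, known or untested is meant among the compounds shown, and "the series" means these compounds.

Compound 1 `O=C(Nc1ccc2[nH]cc(C3CCN(CCCN4CCC(c5c[nH]c6ccc(NC(=O)c7ccc(F)cc7)cc56)CC4)CC3)c2c1)c1ccc(F)cc1` and compound 2 `O=C(Nc1ccc2[nH]cc(C3CCN(CCCCCCN4CCC(c5c[nH]c6ccc(NC(=O)c7ccc(F)cc7)cc56)CC4)CC3)c2c1)c1ccc(F)cc1` each carry two copies of the same indole unit joined through a chain between two ring nitrogens. In an assay on CHO-K1 cells for displacement of a labelled ligand from 5-hydroxytryptamine receptor 1D (Homo sapiens), read by scintillation counting (a higher number here means a weaker inhibitor, a lower number a stronger inhibitor), compound 1 gives 79 nM, and in this assay compound 2 gives 0.6 nM. Compound 3 `CCCCCCCCN1CCC(c2c[nH]c3ccc(NC(=O)c4ccc(F)cc4)cc23)CC1` keeps only one such unit, with an octyl chain on the ring nitrogen. For compound 3 this assay returned a limit rather than a number, > 1000 nM, so its value is only known to sit at or beyond the edge of what the assay resolves (the limit of > 1000 nM in this assay, at which 1 of the 3 values shown sits). Compound 4 `O=C(Nc1ccc2[nH]cc(C3CCN(CCN4CCCCC4)CC3)c2c1)c1ccc(F)cc1` is the structure to be tested next. The change from compound 3 is piperidin-1-yl in place of hexyl on a saturated chain carbon, two bonds along the chain from an amine nitrogen in a ring; the single indole unit and its amide are kept, and a second ring nitrogen appears at the end of a short chain. Within the data shown here, no measured pair isolates this change, so its size in this assay is not known from the data here. Given that compound 3 sits at the limit, compound 4 is expected to stay weak, with a step that the limit leaves unreadable from compound 3 to compound 4 that is not expected to be clearly beyond the scatter in either direction. The estimate for compound 4 in this assay is therefore 1200 nM, within a range from 250 nM to 6000 nM.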

Compound 4, inhibition constant: > 1000 nM
Compound 4: only a limit was reported; the forecaster's own chance of this, stated with the estimate: 45%; the middle value is on the limit's open side.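

In this assay compound 4 returned a limit, > 1000 nM, rather than a number. Compound 3 also sits at a limit, so no step from one to the other can be read: the limit of > 1000 nM in this assay, at which 2 of the 4 values shown sit.

The compounds shown leave open where the true values of compound 3 and compound 4 lie, and so whether piperidin-1-yl in place of hexyl makes any difference in this assay.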